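Clearance and the substituted nitrogen: compound 3 to compound 4

This account rests on a few compounds, and the source may have more. Where it says the series, first, only, none or still open, it means among the compounds named here.

Values in an ADME assay on microsomes from liver (Mus musculus) for metabolic stability, read by HPLC, with a stated time of 4 h (on this read-out higher numbers stand for fast clearance and lower numbers for slow clearance), so far:
- compound 1 `CN(C)c1ccc2cc(-c3cc(Cl)cc(Cl)c3)c(N)nc2c1` gives 210 mL/min/kg
- compound 2 `CN(C)c1ccc2cc(-c3cn(C)c4ccccc34)c(N)nc2c1` gives 210 mL/min/kg
- compound 3 `CNc1ccc2cc(-c3cc(Cl)cc(Cl)c3)c(N)nc2c1` gives < 10 mL/min/kg (a limit of the assay)

Compound 3 stands at the limit of < 10 mL/min/kg in this assay, at which 1 of the 3 values shown sits, and has no exact number. The next structure, compound 4 `Nc1nc2cc(N3CCCC3)ccc2cc1-c1cc(Cl)cc(Cl)c1`, has pyrrolidin-1-yl in place of methylamino on an aromatic carbon. The hydrogen on that nitrogen is therefore gone, as it is in compound 1.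

For the measured compounds named here, one measured step bears on this change: an at least 21-fold lower number from compound 1 to compound 3 (1.32 log units; beyond the scatter) concerns the same nitrogen. Read in reverse, it points to a large rise in this assay on losing that hydrogen. With the same nitrogen group as compound 1 but a different group on the core, compound 2 also gives 210 mL/min/kg in this assay as a second reference. A ring on that nitrogen has not yet been measured, so the size stays uncertain.

The expected change is an at least 15-fold higher number from compound 3 to compound 4 (1.17 log units; beyond the scatter) and it is large, well beyond the scatter. For compound 4 the estimated clearance is 150 mL/min/kg with an expected range of 50 mL/min/kg to 300 mL/min/kg as its limits.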

Compound 4, clearance: 320 mL/min/kg
Estimate against measurement, compound 4: 2.1-fold (0.33 log units) below; the whole stated range lies below it.
By their numbers in this assay, from the lowest: compounds 1, 2 and 4 (each within the scatter of the next). At a limit, below all of these: compound 3.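

In this assay the change gives an at least 32-fold higher number from compound 3 to compound 4 (1.50 log units; beyond the scatter) and so extends to pyrrolidin-1-yl the large difference seen so far only with dimethylamino on this aromatic carbon. The further step, a 1.5-fold higher number from compound 1 to compound 4 (0.18 log units; within the scatter) and within the scatter, means that this assay does not separate the five-membered ring from dimethylamino at this place, and of the three groups tried here only methylamino keeps a hydrogen on the nitrogen. The figure for compound 3 is a limit and not a number: the limit of < 10 mL/min/kg in this assay, at which 1 of the 4 values shown sits.

Going by these compounds, whether the low clearance goes with that hydrogen generally or with methylamino alone stays open, and ethylamino or a plain amino group at this place would separate the two. Also open, on these data alone, is whether a ring with a second hetero atom, such as morpholin-4-yl, stays with pyrrolidin-1-yl and dimethylamino.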